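Swapping an Ester for an Amide on a Shared Core

The compounds below may be only part of what the source reports. "The series", "measured", "known", "first", "only" and "open" are said of these compounds alone.

Measured compounds and values:
compound 1 `COC(=O)C1=C(C)NC(=O)NC1c1ccoc1`: 2%
compound 2 `CC1=C(C(=O)OCc2ccccc2)C(c2ccoc2)NC(=O)N1`: 1%
compound 3 `COC(=O)C1=C(C)N(C)C(=O)NC1c1ccoc1`: 7%

All three compounds were tested in an assay on membranes from HeLa cells for displacement of a labelled ligand from adenosine receptor A3 (Homo sapiens), read by scintillation counting, with a stated time of 180 min, tested at 1 uM; a higher number here means more inhibition at the concentration tested (going by the name of the read-out), a lower number less inhibition. Compound 1 gives a value that lies within the scatter of both neighbours: a number 1 percentage points lower from compound 1 to compound 2 (within the scatter), brought about by phenyl in place of hydrogen on a saturated chain carbon bound to an oxygen next to a carbonyl group, and a number 5 percentage points higher from compound 1 to compound 3 (within the scatter), brought about by methyl in place of hydrogen on an amide-type nitrogen in a ring. Neither step moves the read-out beyond what repeated measurements would show.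

Compound 4 `CCNC(=O)C1=C(C)NC(=O)NC1c1ccoc1` differs from compound 1 in one place: ethylamino in place of methoxy on a carbonyl carbon. For the measured compounds named here, no measured step touches this carbonyl carbon, so the two steps above bear on it only indirectly, and both were small. Nothing in the measured compounds points to a step beyond the scatter for compound 4. In this assay compound 4 is therefore expected to give about 3%, estimated to fall between -6% and 13%. The expected step is a number 1 percentage points higher from compound 1 to compound 4 (within the scatter).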

Compound 4, a percentage reported as inhibition, at one concentration (the size of the read-out at that concentration, not a potency): 1%
Compound 4: middle estimate off by 2 percentage points, on the high side; measured number inside the range.
By their numbers in this assay, from the lowest: compounds 2, 4, 1 and 3 (each within the scatter of the next).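

In this assay, for the compounds shown here, ethylamino in place of methoxy on the carbonyl carbon gives a number 1 percentage points lower from compound 1 to compound 4 (within the scatter) and so provides the first direct reading at this position. The carbonyl carbon can therefore carry ethylcarbamoyl instead of methoxycarbonyl, with a hydrogen-bond donor entering and a hydrogen-bond acceptor leaving, without a step beyond the scatter at the single concentration tested. Nothing shown here gives a reason for this result.

Still open, from the compounds shown here alone, is whether a carboxylic acid, or a longer chain such as butylamino, on this carbonyl carbon would move the read-out beyond the scatter. Going by these compounds, it is also open whether ethylamino would give an equally small step on the core of compound 3, which carries the methyl on the amide-type nitrogen in the ring.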